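Dropping One Phenyl Group from Compound 1

A few compounds are considered here, and "the series" means these few. Any claim that something is new, unique, unknown or untested is made for them only; others in the source may bear on it.

Measured so far:
compound 1, `CCC(C)C(NC(=O)NO)C(=O)NC(c1ccccc1)c1ccccc1`, 56000 nM
compound 2, `CCC(C)C1NC(=O)N(C2CCCC2)C1=O`, > 200000 nM
compound 3, `CCC(C)C(NC(=O)n1nnc2ccccc21)C(=O)NC(c1ccccc1)c1ccccc1`, 79000 nM

In a functional assay on MOLT-4 cells (Homo sapiens) for inhibition (on this read-out lower numbers stand for stronger inhibition and higher numbers for weaker inhibition), compound 1 gives 56000 nM, the lowest of the two numbers shown. Compound 3 gives 79000 nM, and the step of a 1.4-fold higher number from compound 1 to compound 3 (0.15 log units; within the scatter) lies within the scatter, so the two cannot be ranked. For compound 2 this assay reports only a limit, > 200000 nM, not a number (the limit of > 200000 nM in this assay, at which 1 of the 3 values shown sits).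

Compound 4, `CCC(C)C(NC(=O)NO)C(=O)NCc1ccccc1`, differs from compound 1 by hydrogen in place of phenyl on a saturated chain carbon bound to an amide-type nitrogen and an aromatic carbon. Among the measured compounds shown here, no measured step touches that position: the one step known, a 1.4-fold higher number from compound 1 to compound 3 (0.15 log units; within the scatter), alters the group on the carbonyl carbon instead and changed little. The expectation for compound 4 therefore rests on little evidence. Compound 4 is expected to give about 120000 nM, between 40000 nM and 400000 nM. The expected step is a 2.1-fold higher number from compound 1 to compound 4 (0.33 log units; beyond the scatter), toward weaker inhibition.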

Compound 4, half-maximal inhibitory concentration: 126000 nM
Beside the measured number, compound 4's estimate is 1.1-fold (0.02 log units) below it, within the range that was stated.
By their numbers in this assay, from the lowest: compounds 1, 3 and 4 (each within the scatter of the next, the first and the last beyond it). At a limit, above all of these: compound 2.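

This is the first step shown at this position, on a saturated chain carbon bound to an amide-type nitrogen and an aromatic carbon. In this assay, hydrogen in place of phenyl gives a 2.3-fold higher number from compound 1 to compound 4 (0.35 log units; beyond the scatter), so the position responds to this change, if only modestly, whereas the change on the carbonyl carbon stayed within the scatter. No measurement shown accounts for this step.

Going by these compounds, whether a methyl group at this position would give a number nearer that of compound 1 or that of compound 4 remains open. So does the effect of an amine on the remaining phenyl ring.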